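Compound 2 to compound 4: substitution on the oxygen

The source may hold more compounds than are shown below. What is called first, only, known or untested is meant among the compounds shown, and "the series" means these compounds.

Of the compounds shown here, three sharing one core have been measured in an ADME assay on BJ cells (Homo sapiens) for cytotoxicity, read by CellTiter-Glo, with a stated time of 72 h; a lower number here means that less compound is needed, a higher number that more compound is needed for the effect. Compound 1 (`CC1=C2CC(C)(C)/C=C/C(=O)/C(C)=C\C3=C[C@H](C)C[C@]3(O2)[C@]1(C)O`) gives 26000 nM, and compound 3 (`CC1=C2CC(C)(C)/C=C/[C@@H](O)/C(C)=C\C3=C[C@H](C)C[C@]3(O2)C1=O`) gives 26000 nM. Compound 2 (`CC1=C2CC(C)(C)/C=C/[C@H](O)/C(C)=C\C3=C[C@H](C)C[C@]3(O2)C1=O`) gives 10600 nM, the lowest of the three numbers, and both other compounds lie beyond the scatter from it.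

The next structure, compound 4 (`CC1=C2CC(C)(C)/C=C/[C@H](OC(=S)n3ccnc3)/C(C)=C\C3=C[C@H](C)C[C@]3(O2)C1=O`), is related to compound 2 by a group of 7 heavy atoms (4 carbon, 2 nitrogen, 1 sulfur; one five-membered aromatic ring with 2 hetero atoms) in place of a hydrogen atom, on an oxygen on a saturated carbon. Among the compounds with values here, the group is new to the series, so no measured compound carries it or anything like it.

Within the data shown here, only one measured step bears on this change: a 2.5-fold higher number from compound 2 to compound 3 (0.39 log units; beyond the scatter). It concerns the configuration at the saturated carbon that carries the same oxygen, and the gap goes with the fact that compounds 2 and 3 differ only in the configuration as drawn. It is a modest step, and it shows that this assay responds to a change at this carbon, but it says nothing about a group added to the oxygen. No direction can be drawn from it, so no shift beyond the scatter is expected, though the uncertainty is wide on both sides.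

The expected change is a 1.2-fold lower number from compound 2 to compound 4 (0.07 log units; within the scatter). For compound 4 the estimated value is 9000 nM, with an expected range from 3000 nM to 26000 nM.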

Compound 4, half-maximal effective concentration: 26000 nM
Beside the measured number, compound 4's estimate is 2.9-fold (0.46 log units) below it; the measured number falls inside the stated range.
By their numbers in this assay, from the lowest: compound 2; then compounds 1, 3 and 4 (each within the scatter of the next).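

In this assay, replacing the hydrogen on this oxygen gives a 2.5-fold higher number from compound 2 to compound 4 (0.39 log units; beyond the scatter), so the assay responds to substitution on the oxygen as well as to the configuration of the saturated carbon that carries it. The shift is modest and runs in the same direction as the earlier change at this carbon, a 2.5-fold higher number from compound 2 to compound 3 (0.39 log units; beyond the scatter), so both single changes measured from compound 2 give a higher number. The earlier step alone could not show this, as it involves no new atoms: the fact that compounds 2 and 3 differ only in the configuration as drawn.

The compounds shown leave open whether the higher number for compound 4 follows from the loss of the hydrogen on the oxygen or from the particular group that enters, with its five-membered aromatic ring and its double bond outside that ring; a methyl ether or an acetyl ester on the same oxygen would bear on that question. They also leave open whether a group on this oxygen shifts the number in the same way when the saturated carbon has the configuration drawn in compound 3.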